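A few compounds are considered here, and "the series" means these few. Any claim that something is new, unique, unknown or untested is made for them only; others in the source may bear on it.

In a functional assay on MDA-MB-231 cells (Homo sapiens) for antiproliferative activity, read by XTT assay (a lower number here means a stronger inhibitor, a higher number a weaker inhibitor), three compounds have been tested so far, and none of them gives a number. Compound 1 `O=c1c(Cc2coc3cccc(OCC4CCCCC4)c3c2=O)coc2cc(Cl)ccc12` is reported as > 10000 nM, which is a limit. Compound 2 `CC(C)COc1cccc2occ(Cc3coc4ccccc4c3=O)c(=O)c12` is reported as > 10000 nM, also a limit. Compound 3 `CC(C)CCOc1cccc2occ(Cc3coc4ccccc4c3=O)c(=O)c12` is reported as > 10000 nM, again a limit. Compound 1 therefore stands at the limit of > 10000 nM in this assay, at which 3 of the 3 values shown sit, with no number of its own.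

Compound 4 `O=c1c(Cc2coc3cccc(OCC4CCCCC4)c3c2=O)coc2cc(O)ccc12` departs from compound 1 by a single exchange, hydroxy in place of chloro on an aromatic carbon. For the measured compounds named here, the only measured step in the set is a step that the two limits leave unreadable from compound 2 to compound 3. It concerns a different group and offers no size to carry over to this exchange. With no readable step to draw on, no shift beyond the scatter is expected in this assay, in either direction. That expectation leans only on compound 1, whose value is the limit > 10000 nM. The estimated change, a step that the limit leaves unreadable from compound 1 to compound 4, is therefore expected to be small and remains poorly defined. Compound 4 is estimated at 15000 nM, with an expected range from 5000 nM to 50000 nM, and a report as a limit is the likeliest outcome.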

Compound 4, half-maximal inhibitory concentration: 3220 nM
The estimate for compound 4 lay 4.7-fold (0.67 log units) above the measured number; measured number below the stated range.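

For the compounds shown here, the exchange of chloro for hydroxy on this aromatic carbon, meta to a fused ring and para to a fused ring, gives the first readable step in this assay: an at least 3.1-fold lower number from compound 1 to compound 4 (0.49 log units; beyond the scatter). Going by these compounds alone, the step lies beyond the scatter, whereas the one earlier step, between compound 2 and compound 3, cannot be read, so this position is the first place in the set where a single exchange is seen to matter. Compound 4 is also the only compound shown with a number rather than a limit, which sets it apart from the other three: the limit of > 10000 nM in this assay, at which 3 of the 4 values shown sit.

The full size of the step stays open, since compound 1 has no number of its own, and the compounds shown cannot tell whether the gain comes from the hydrogen-bond donor that enters with hydroxy or from the loss of chloro, a question that a methoxy or an amine on the same carbon would bear on. They also leave open whether hydroxy at this place would act in the same way alongside the ether chains of compound 2 and compound 3 rather than the cyclohexylmethyl ether of compound 4.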